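The source may report more compounds than this note shows. Statements on the series, on what has been measured and on what is new or still open speak of the compounds shown alone.

Of the compounds shown here, three have been measured. Compound 1 `O=C(Nc1cccc(O)c1)c1nccc2ccccc12` gives only a limit of the assay, > 10000 nM. Compound 2 `O=C(Nc1cccc(C(F)(F)F)c1)c1nccc2ccccc12` likewise gives only a limit, > 10000 nM. Compound 3 `O=C(Nc1ccccc1C(F)(F)F)C1NCCc2ccccc21` also gives only a limit, > 10000 nM.

All of these come from a functional assay on NUGC-3 cells (Homo sapiens) for inhibition, read by sulforhodamine B assay, with a stated time of 48 h; on this read-out higher numbers stand for weaker inhibition of growth and lower numbers for stronger inhibition of growth. From compound 2 to compound 1 the change is hydroxy in place of trifluoromethyl on an aromatic carbon, and the step it made is a step that the two limits leave unreadable from compound 2 to compound 1. Compound 3 carries a different core; the difference between the two cores is not broken down here. Compound 4 `O=C(Nc1ccccc1O)C1NCCc2ccccc21` arises from compound 3 by hydroxy in place of trifluoromethyl on an aromatic carbon. This is the same kind of change as before, though here the hydroxy sits ortho to a large group rather than meta to a large group. Going by the values given here, every value so far is the limit of > 10000 nM in this assay, at which 3 of the 3 values shown sit. Beside the earlier step, the step expected here is a step that the limit leaves unreadable from compound 3 to compound 4, an expectation resting on (the limit of > 10000 nM in this assay, at which 3 of the 3 values shown sit). Compound 4 is therefore estimated at 20000 nM.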

Compound 4, concentration for 50% growth inhibition: > 10000 nM
Compound 4 was reported as a limit; the forecaster's own chance of this, stated with the estimate: 80%; the middle value does not contradict the limit.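

Compound 3 and compound 4 are both reported only as limits, and no size can be read for the step between them. The compounds shown leave open whether hydroxy in place of trifluoromethyl changes anything in this assay.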